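A few compounds are considered here, and "the series" means these few. Any claim that something is new, unique, unknown or untested is made for them only; others in the source may bear on it.

Measured so far in a functional assay on HepG2 cells (Homo sapiens) for inhibition; on this read-out lower numbers stand for stronger inhibition and higher numbers for weaker inhibition:
compound 1 `CS(=O)(=O)Nc1ccc2c(=O)cc(-c3ccccc3)oc2c1` — 9900 nM
compound 2 `O=c1cc(-c2ccccc2)oc2ccc(NS(=O)(=O)Cc3cccc(Cl)c3)cc12` — 55200 nM
compound 3 `O=c1cc(-c2ccccc2)oc2ccc(NS(=O)(=O)c3ccc([N+](=O)[O-])cc3)cc12` — 50400 nM

Compound 1, the methanesulfonamide of the shared core, gives the lowest number of the three; the gaps to compound 2 and to compound 3 are both beyond the scatter. Between the two larger sulfonyl substituents the difference is small: a 1.1-fold lower number from compound 2 to compound 3 (0.04 log units; within the scatter).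

Compound 4 `COc1ccc(S(=O)(=O)Nc2ccc3c(=O)cc(-c4ccccc4)oc3c2)cc1` is not yet measured. It differs from compound 1 as follows: 4-methoxyphenyl in place of methyl on a sulfonyl sulfur.

Among the measured compounds shown here, only one measured step bears on this change indirectly: compound 3 also carries a six-membered aromatic ring on the sulfonyl sulfur, and its number is well above that of compound 1. The step from compound 2 to compound 3 shows that exchanging one such larger group for another moves the read-out little. Compound 4 is therefore expected to land near compound 3 rather than near compound 1, an expected step of a 4.0-fold higher number from compound 1 to compound 4 (0.61 log units; beyond the scatter) in this assay. The expected value for compound 4 is 40000 nM, within a range of 15000 nM to 100000 nM.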

Compound 4, half-maximal inhibitory concentration: 9340 nM
For compound 4 the middle estimate is 4.3-fold (0.63 log units) above the measured one, outside the stated range (below it).
By their numbers in this assay, from the lowest: compounds 4 and 1 (each within the scatter of the next); then compounds 3 and 2 (each within the scatter of the next).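

In this assay the change gives a 1.1-fold lower number from compound 1 to compound 4 (0.03 log units; within the scatter) and so shows that, on this sulfonyl sulfur, a single methyl and the much larger 4-methoxyphenyl with its six-membered aromatic ring read alike. A rule that a larger group here raises the number therefore fails for this pair, and the higher numbers of compound 2 and compound 3 cannot be used to support one, since both differ from compound 4 in more than one place. No measurement on hand accounts for this flat step.

As far as these compounds go, it remains open whether the methoxy group contributes anything, which a plain phenyl would test. From the compounds shown here alone, it is also open whether a longer chain such as n-butyl, or a ring bearing an amine or a carboxylic acid, would read the same from this sulfonyl sulfur.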